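The source may hold more compounds than are shown below. What is called first, only, known or untested is meant among the compounds shown, and "the series" means these compounds.

Measured so far:
compound 1 `CO[C@H]1CC[C@H](Nc2cc(NCc3cnccc3C(F)(F)F)ncc2C#N)CC1` — > 10000 nM
compound 2 `N#Cc1cnc(NCc2cncnc2OCC(F)F)cc1N[C@H]1CC[C@@H](O)CC1` — 90 nM

In an assay on isolated protein for inhibition of protein kinase C delta type (Homo sapiens), read by TR-FRET, with a stated time of 2 h (on this read-out higher numbers stand for weaker inhibition and lower numbers for stronger inhibition), compound 1 returns > 10000 nM, which is a limit of the assay and not a number. Compound 1 therefore has no fixed place among the values shown; what is known of it is only (the limit of > 10000 nM in this assay, at which 1 of the 2 values shown sits). In this assay compound 2 gives 90 nM. Within the data shown here, compound 2 carries a hydroxyl on its saturated ring and a different arm on the other side of the shared core, so no single step between compound 1 and compound 2 is set out; only the two values themselves can be compared.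

Compound 3 `CC1(C)C[C@H](Nc2cc(NCc3cnccc3C(F)(F)F)ncc2C#N)CC[C@@H]1O` is not yet measured. It differs from compound 1 by 4-hydroxy-3,3-dimethylcyclohexyl in place of 4-methoxycyclohexyl on a nitrogen on an aromatic ring; a hydrogen-bond donor enters with the change. With compound 1 at a limit, only a direction can be expected. The expected step is an at least 3.3-fold lower number from compound 1 to compound 3 (0.52 log units; beyond the scatter), toward stronger inhibition, given that compound 2 gives 90 nM with a hydroxyl on its ring. Compound 3 is estimated at 3000 nM, within 400 nM to 20000 nM.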

Compound 3, half-maximal inhibitory concentration: 500 nM
Compound 3: the middle estimate sits 6.0-fold (0.78 log units) above what was measured; low and high end bracket the measured number.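

In this assay, 4-hydroxy-3,3-dimethylcyclohexyl in place of 4-methoxycyclohexyl on a nitrogen on an aromatic ring gives an at least 20-fold lower number from compound 1 to compound 3 (1.30 log units; beyond the scatter). Among these compounds, this is the first step that can be read at a single place: with the rest of the structure unchanged, the change at this nitrogen substituent alone brings compound 3 to a measured 500 nM. The step has no upper bound because compound 1 stands at a limit of the assay, not at a number: the limit of > 10000 nM in this assay, at which 1 of the 3 values shown sits.

The change brings the hydroxyl and the 3,3-dimethyl substitution together, so the compounds shown do not separate their contributions. From the compounds shown here alone, how a 4-aminocyclohexyl or a 4-carboxycyclohexyl group would read at this place also remains open.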